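A few compounds are considered here, and "the series" means these few. Any claim that something is new, unique, unknown or untested is made for them only; others in the source may bear on it.

Two compounds share one core and differ only in the group carried on a saturated chain carbon bound to an oxygen on an aromatic ring. Compound 1 `N#Cc1ccccc1COc1ccc(-c2cc(CN3CCN(Cc4ccc(C(F)(F)F)cc4)CC3)no2)cc1` bears a 2-cyanophenyl there; in a functional assay on Huh-7 cells (Homo sapiens) for antiproliferative activity, read by sulforhodamine B assay, with a stated time of 72 h (on this read-out lower numbers stand for stronger inhibition and higher numbers for weaker inhibition), compound 1 gives 5000 nM. Compound 2 `N#Cc1cccc(COc2ccc(-c3cc(CN4CCN(Cc5ccc(C(F)(F)F)cc5)CC4)no3)cc2)c1` carries a 3-cyanophenyl in its place, and in this assay compound 2 gives 100 nM. Compound 2 thus stands lowest of the two numbers, and the step of a 50-fold lower number from compound 1 to compound 2 (1.70 log units; beyond the scatter) shows how strongly a change in this one group can move the read-out.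

Compound 3 `COc1cc(COc2ccc(-c3cc(CN4CCN(Cc5ccc(C(F)(F)F)cc5)CC4)no3)cc2)cc(OC)c1` is not yet measured. It differs from compound 2 by 3,5-dimethoxyphenyl in place of 3-cyanophenyl on a saturated chain carbon bound to an oxygen on an aromatic ring. Among the measured compounds shown here, no measured step exchanges the nitrile-bearing ring for a ring bearing methoxy groups, so the only guidance is the step of a 50-fold lower number from compound 1 to compound 2 (1.70 log units; beyond the scatter), which tells that this region of the molecule can shift the number a great deal without saying in which direction the present change will go. Compound 3 is therefore expected to give 500 nM, with a range from 80 nM to 5000 nM. This estimate corresponds to an expected step of a 5.0-fold higher number from compound 2 to compound 3 (0.70 log units; beyond the scatter).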

Compound 3, half-maximal inhibitory concentration: 1500 nM
For compound 3 the middle estimate is 3.0-fold (0.48 log units) below the measured one, within the range that was stated.
By their numbers in this assay, from the lowest: compound 2; then compound 3; then compound 1.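

In this assay, the earlier pair showed only that moving the nitrile on the ring changes the number, whereas this result shows what happens when the nitrile-bearing ring gives way to a differently substituted one: 3,5-dimethoxyphenyl in place of 3-cyanophenyl brings a 15-fold higher number from compound 2 to compound 3 (1.18 log units; beyond the scatter) and so a clear loss of inhibition. The same group still does better than 2-cyanophenyl, with a 3.3-fold lower number from compound 1 to compound 3 (0.52 log units; beyond the scatter), so a ring without a nitrile can hold a place between the two cyanophenyl compounds, and the nitrile itself is not required for activity at this level, although the best number of the three still belongs to compound 2. Nothing measured here gives a reason for either step.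

Compound 3 differs from compound 2 both in the kind of group and in how many groups the ring carries, so these compounds leave open whether a ring with a single methoxy group would behave like compound 2 or like compound 3. They also leave open how this position would respond to a ring bearing an amine or a carboxylic acid, or to a longer chain between the ring and the oxygen.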